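The source may report more compounds than this note shows. Statements on the series, on what has been measured and on what is new or still open speak of the compounds shown alone.

Of the compounds shown here, three of one shared core have been measured. Compound 1 `CCCc1cc(N)c2cc(NC(=O)/C=C/c3ccc(N)cc3)ccc2n1` gives 190 nM in an assay on isolated protein for displacement of a labelled ligand from melanin-concentrating hormone receptor 1 (Homo sapiens); a lower number here means a stronger inhibitor, a higher number a weaker inhibitor. Compound 2 `CCCc1cc(NC2CC2)c2cc(NC(=O)/C=C/c3ccc(C(F)(F)F)cc3)ccc2n1` gives 40 nM in this assay, which places it second highest of the three numbers. Compound 3 `Nc1cc(C2CCCCC2)nc2ccc(NC(=O)/C=C/c3ccc(C(F)(F)F)cc3)cc12` gives 1.2 nM in this assay. Set against compound 2, the number for compound 1 is higher and the number for compound 3 is lower, and both of those gaps lie beyond the usual scatter of repeated measurements. Going by the values given here, none of these three pairs differs in a single place, so no isolated step is available from which the effect of one change could be read.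

Compound 4 `CCCc1cc(OC)c2cc(NC(=O)/C=C/c3ccc(C(F)(F)F)cc3)ccc2n1` has not been measured. It departs from compound 2 by methoxy in place of cyclopropylamino on an aromatic carbon. Among the compounds with values here, no measured pair isolates this change. The direction can only be guessed from the three numbers at hand. Compound 2 carries the group that leaves and gives 40 nM, so compound 4 is expected to drift toward a somewhat higher number without moving far. The step from compound 2 to compound 4 is estimated at a 2.5-fold higher number from compound 2 to compound 4 (0.40 log units; beyond the scatter). Compound 4 is therefore expected to give about 100 nM in this assay, with a plausible range from 25 nM to 400 nM.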

Compound 4, half-maximal inhibitory concentration: 26 nM
The estimate for compound 4 lay 3.8-fold (0.59 log units) above the measured number, and the stated range covers the measured number.
By their numbers in this assay, from the lowest: compound 3; then compounds 4 and 2 (each within the scatter of the next); then compound 1.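

In this assay, going by these compounds alone, methoxy in place of cyclopropylamino on the aromatic carbon opposite the ring nitrogen gives a 1.5-fold lower number from compound 2 to compound 4 (0.19 log units; within the scatter) as the first step at this position that can be read on its own, and compound 2 and compound 4 cannot be told apart. With the rest of the molecule held constant, this exchange removes the three-membered carbon ring and the hydrogen-bond donor of cyclopropylamino without a difference beyond the scatter, so in this pair neither feature is needed to keep the number in this range. No measurement shown gives a reason for this result.

The compounds shown leave open whether other groups at this position, such as ethoxy, hydroxyl or dimethylamino, would also stay within the scatter of compound 2. They also leave open whether the same exchange would give a similar step with cyclohexyl in place of the propyl group, or with another group in place of trifluoromethyl, such as a nitrile.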